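A Chloro in Place of Fluoro on Compound 3

The compounds below may be only part of what the source reports. "The series", "measured", "known", "first", "only" and "open" are said of these compounds alone.

Of the compounds shown here, three have been measured in a functional assay (aorta) with Oryctolagus cuniculus as the target (on this read-out lower numbers stand for stronger inhibition and higher numbers for weaker inhibition), so far. Compound 1 `CC1=C(C)C(=O)C(C(CCCCCCC(=O)O)c2ccccc2)=C(C)C1=O` sits at 3200 nM and compound 2 `CC1=C(C(CCCCCC(=O)O)c2ccccc2)C(=O)c2ccccc2C1=O` at 240 nM on this scale. Compound 3 `CC1=C(C)C(=O)C(C(CCCCCC(=O)O)c2ccc(F)cc2)=C(C)C1=O` has the lowest number of the three, and so the strongest inhibition, at 48 nM with both other compounds lying beyond the usual scatter from it.

Compound 4 `CC1=C(C)C(=O)C(C(CCCCCC(=O)O)c2ccc(Cl)cc2)=C(C)C1=O` has not yet been measured. It differs from compound 3 in one place only, on an aromatic carbon of a six-membered aromatic ring of carbon only, para to a large group, where chloro stands in place of fluoro (chloro in place of fluoro on an aromatic carbon).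

Among the measured compounds shown here, none of the measured compounds differ from one another at this place alone, so the data offer no direct precedent for this change. The change itself is small, and no step beyond the scatter is expected in this assay for it, with at most a slight rise in the number. The expected size of the change is given by the estimated step of a 1.3-fold higher number from compound 3 to compound 4 (0.10 log units; within the scatter) and stays within the usual scatter. Compound 4 is expected at 60 nM (estimated range 20 nM to 180 nM).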

Compound 4, half-maximal inhibitory concentration: 280 nM
Estimate against measurement, compound 4: 4.7-fold (0.67 log units) below; measured number outside the range, above it.
By their numbers in this assay, from the lowest: compound 3; then compounds 2 and 4 (each within the scatter of the next); then compound 1.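

In this assay, chloro in place of fluoro is the first change at a single place that can be read among these compounds, and it gives a 5.8-fold higher number from compound 3 to compound 4 (0.77 log units; beyond the scatter). This shows that the aromatic carbon para to a large group is not indifferent to which halogen it carries: one heavy atom is exchanged for one heavy atom, with no change in ring count, hydrogen-bond donors, hydrogen-bond acceptors or net charge, and the step still lies beyond the scatter, with the 4-fluorophenyl compound holding the lower number. Nothing available here bears on why the step has this size.

From the compounds shown here alone, how bromo, methyl or methoxy would read at this same place on the shared core remains open, so a single pair cannot show whether the number follows any trend across groups. Also open, going by these compounds, is whether the step from 4-fluorophenyl to 4-chlorophenyl would keep its size alongside the chain of compound 1 or the core of compound 2.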